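Hydroxy to methoxy repeated on a second core

The source may hold more compounds than are shown below. What is called first, only, known or untested is meant among the compounds shown, and "the series" means these compounds.

Compound 1 `COc1ccc(-c2cc3ccccc3c(-c3cccc(O)c3)n2)cc1` and compound 2 `COc1ccc(-c2cc3ccccc3c(-c3cccc(OC)c3)n2)cc1` share one core; compound 3 `COc1ccc(-c2cc3cc(C)ccc3c(-c3ccc(O)cc3)n2)cc1OC` and compound 4 `COc1ccc(-c2nc(-c3ccc(OC)c(OC)c3)cc3cc(C)ccc23)cc1` share another. The difference between the two cores is not broken down here. In a functional assay on HCT-15 cells (Homo sapiens) for cytotoxicity, read by CCK-8 assay and cell counting, with a stated time of 72 h (a lower number here means a stronger inhibitor, a higher number a weaker inhibitor), compound 1 gives 1200 nM, and compound 2 gives 1300 nM. The change between them, (methyl in place of hydrogen on an oxygen on an aromatic ring), made a step of a 1.1-fold higher number from compound 1 to compound 2 (0.03 log units; within the scatter).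

Compound 3 in this assay gives 2520 nM, the highest of the three numbers; against compound 2 the gap is within the scatter, against compound 1 it is beyond it. The change from compound 3 to compound 4, (methyl in place of hydrogen on an oxygen on an aromatic ring), is the same change as the earlier one: the leaving and entering groups match, and the place, on an oxygen on an aromatic ring whose other neighbours are aromatic carbon, is the same; only the reading one bond further out differs, 4-hydroxyphenyl to 4-methoxyphenyl in place of 3-hydroxyphenyl to 3-methoxyphenyl.

Among the compounds with values here, for compound 4 a step of a 1.1-fold higher number from compound 3 to compound 4 (0.05 log units; within the scatter) is expected, resting on the single earlier step of a 1.1-fold higher number from compound 1 to compound 2 (0.03 log units; within the scatter) that stayed within the scatter. Compound 4 is therefore estimated at 2800 nM, between 1400 nM and 5600 nM.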

Compound 4, half-maximal inhibitory concentration: 28700 nM
Compound 4: middle estimate off by 10-fold (1.01 log units), on the low side, and the stated range ends below it.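

In this assay, methyl in place of hydrogen on the oxygen gives an 11-fold higher number from compound 3 to compound 4 (1.06 log units; beyond the scatter), so the size of this change did not carry over from the core of compound 1 to the core of compound 3: the same change on two cores in this assay, a 1.1-fold higher number (0.03 log units; within the scatter) from compound 1 to compound 2 and an 11-fold higher number (1.06 log units; beyond the scatter) from compound 3 to compound 4, 11-fold (1.02 log units) apart, beyond the scatter of two such steps

A small step on one core is therefore no safe guide to the same change on another core in this series, and a single earlier pair gives too little ground for such a transfer. This does not show what sets the two steps apart, since they differ both in the core and in the reading one bond further out, here 4-hydroxyphenyl to 4-methoxyphenyl, and one pair per core cannot separate these two differences.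

The compounds shown leave open whether the large step belongs to the core of compound 3 or to where the hydroxy group stands on the phenyl ring. Also open, as far as these compounds go, is how a group other than methyl on that oxygen, such as a longer chain or a chain ending in an amine, would read on either core.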